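A few compounds are considered here, and "the series" means these few. Any claim that something is new, unique, unknown or untested is made for them only; others in the source may bear on it.

Working notes on the series. The shared core of compound 1 `CCC1=C(O)c2c(oc(-c3ccc(SC)cc3)cc2=O)C(CC)(CC)C1=O` carries a 4-(methylsulfanyl)phenyl group. In a functional assay on KB cells (Homo sapiens) for antiproliferative activity, read by sulforhodamine B assay, with a stated time of 3 days (on this read-out higher numbers stand for an effect only at larger amounts of compound and lower numbers for an effect already at smaller amounts), compound 1 returns only a limit, > 52.1 uM, and no number. Compound 2 `CCC1=C(O)c2c(oc(-c3ccc(OC)c(C)c3C)cc2=O)C(CC)(CC)C1=O` gives 5.43 uM in this assay. Compound 3 `CCC1=C(O)c2c(oc(-c3cc(OC)c(OC)c(OC)c3)cc2=O)C(CC)(CC)C1=O` gives 46.7 uM in this assay. Compound 1 thus stands at the weak end of what is shown, since (the limit of > 52.1 uM in this assay, at which 1 of the 3 values shown sits). Going by the values given here, no pair of measured compounds differing in a single place is available, so no measured step can be stated.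

Compound 4 `CCC1=C(O)c2c(oc(-c3cc(C)c(O)c(C)c3)cc2=O)C(CC)(CC)C1=O` differs from compound 1 by 4-hydroxy-3,5-dimethylphenyl in place of 4-(methylsulfanyl)phenyl on an aromatic carbon.

For this assay a step from compound 1 to compound 4 toward lower concentrations is expected, beyond the usual scatter, with the open-ended limit of compound 1 leaving its exact size uncertain. Among the compounds with values here, the aryl group nearest in this set to that of compound 4 is the one of compound 2, and compound 2 gives 5.43 uM, which sets the optimistic end of the expectation. Compound 4 is estimated at 15 uM, with a plausible range from 4 uM to 60 uM, corresponding to an expected step of an at least 3.4-fold lower number from compound 1 to compound 4 (0.54 log units; beyond the scatter).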

Compound 4, concentration for half-maximal effect: 18.3 uM
Compound 4: the middle estimate sits 1.2-fold (0.09 log units) below what was measured; measured number inside the range.
By their numbers in this assay, from the lowest: compound 2; then compound 4; then compound 3. At a limit, above all of these: compound 1.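

In this assay, going by these compounds alone, replacing 4-(methylsulfanyl)phenyl with 4-hydroxy-3,5-dimethylphenyl on this aromatic carbon gives the first readable step at this position of the shared core, an at least 2.8-fold lower number from compound 1 to compound 4 (0.45 log units; beyond the scatter). Compound 1 is read only as a limit, > 52.1 uM, so the step gives a minimum and not a size, because its starting point is not a number: the limit of > 52.1 uM in this assay, at which 1 of the 4 values shown sits. Within the data shown here, the entering group carries a hydrogen-bond donor and the leaving group carries none, and the sulfur of the leaving group gives way to an oxygen, so this position accepts a donor-bearing aryl group with compound 4 at 18.3 uM, though the single change does not show which of these differences matters.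

On these data alone, whether the step belongs to the hydroxy group, to the two methyl groups or to the loss of the methylsulfanyl group stays open, since all of these change together in this one pair. Also open, as far as these compounds go, is how an amine or a carboxylic acid in place of the hydroxy group would read in this assay.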